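Amide-to-sulfonamide swap on a shared core

The source may hold more compounds than are shown below. What is called first, only, known or untested is meant among the compounds shown, and "the series" means these compounds.

Measured so far, in a functional assay on A549 cells (Homo sapiens) for antiproliferative activity, read by MTT assay, with a stated time of 72 h; a lower number here means a stronger inhibitor, a higher number a weaker inhibitor:
Compound 1 `CCC(=O)N(C)c1ccc2[nH]c(-c3n[nH]c4ccccc34)cc2n1` gives 15700 nM.
Compound 2 `CN(C(=O)c1ccc(Cl)cc1)c1ccc2[nH]c(-c3n[nH]c4ccccc34)cc2n1` gives 2220 nM.
Compound 3 `COc1cccc(C(=O)N(C)c2ccc3[nH]c(-c4n[nH]c5ccccc45)cc3n2)c1` gives 14900 nM.

Compound 3 sits second highest of the three numbers. Its nearest neighbour is compound 1, within the scatter; the gap to compound 2 is beyond the scatter, as a 6.7-fold higher number from compound 2 to compound 3 (0.83 log units; beyond the scatter) shows.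

Compound 4 `CN(c1ccc2[nH]c(-c3n[nH]c4ccccc34)cc2n1)S(=O)(=O)c1ccc(Br)cc1` is not yet measured. Relative to compound 3 the change is (4-bromophenyl)sulfonyl in place of (3-methoxyphenyl)carbonyl on a nitrogen on an aromatic ring. Going by the values given here, two measured steps bear on it in part. Halogen-bearing aryl on the carbonyl carbon gave the lowest number of the set, with a 7.1-fold lower number from compound 1 to compound 2 (0.85 log units; beyond the scatter) and a 6.7-fold higher number from compound 2 to compound 3 (0.83 log units; beyond the scatter) both beyond the scatter and modest in size. Among the compounds with values here, no measured step covers the carbonyl-to-sulfonyl swap itself, nor bromine in place of chlorine, so that part of the change is untested here.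

Compound 4 is therefore expected to come in lower than compound 3, with a step about the size of a 4.3-fold lower number from compound 3 to compound 4 (0.63 log units; beyond the scatter) and wide uncertainty. The estimate for compound 4 in this assay is 3500 nM, in a range from 900 nM to 14000 nM.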

Compound 4, half-maximal inhibitory concentration: 19700 nM
For compound 4 the middle estimate is 5.6-fold (0.75 log units) below the measured one, outside the stated range (above it).
By their numbers in this assay, from the lowest: compound 2; then compounds 3, 1 and 4 (each within the scatter of the next).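

Notes on the substituent on the nitrogen: in this assay, the (4-bromophenyl)sulfonyl group does not keep the low number of the 4-chlorophenyl amide (an 8.9-fold higher number from compound 2 to compound 4 (0.95 log units; beyond the scatter)), so a halogen-bearing aryl group on this nitrogen does not by itself give the result seen with compound 2. Against the other two amides the new group cannot be told apart (a 1.3-fold higher number from compound 3 to compound 4 (0.12 log units; within the scatter) and a 1.3-fold higher number from compound 1 to compound 4 (0.10 log units; within the scatter)), which leaves compound 2 as the only one of the four that stands clear of the rest, while propanoyl, (3-methoxyphenyl)carbonyl and (4-bromophenyl)sulfonyl sit level within the scatter. Nothing in hand explains why the sulfonyl compound behaves this way.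

As far as these compounds go, the step from compound 2 to compound 4 changes carbonyl to sulfonyl and chlorine to bromine together, so the share of each stays open; a (4-chlorophenyl)sulfonyl or (4-bromophenyl)carbonyl group on the same nitrogen would separate them. Also open, from the compounds shown here alone, is how an amine or a carboxylic acid on the aryl ring would read in this assay, and whether a hydrogen in place of the methyl on this nitrogen would shift any of these numbers.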